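A Pyrazole Reattached: Urea Inhibitors of Intestinal Cholesterol Esterification

The compounds below may be only part of what the source reports. "The series", "measured", "known", "first", "only" and "open" are said of these compounds alone.

compound 1 `Cc1cc(C)c(NC(=O)N(Cc2ccc(-c3ccsc3)cc2)C2CCCCCC2)c(C)c1` — 19 nM
compound 2 `Cc1cc(C)c(NC(=O)N(Cc2ccc(-n3cccn3)cc2)C2CCCCCC2)c(C)c1` — 70 nM

Among the compounds with values here, in an assay on microsomes from intestine for inhibition of acyl-CoA:cholesterol acyltransferase (Oryctolagus cuniculus) (a lower number here means a stronger inhibitor, a higher number a weaker inhibitor), compound 2 stands highest of the two numbers; its nearest neighbour is compound 1, and the only measured step is a 3.7-fold higher number from compound 1 to compound 2 (0.57 log units; beyond the scatter). Compound 3 `Cc1cc(C)c(NC(=O)N(Cc2ccc(-c3cn[nH]c3)cc2)C2CCCCCC2)c(C)c1` differs from compound 2 in one place: 1H-pyrazol-4-yl in place of 1H-pyrazol-1-yl on an aromatic carbon. Within the data shown here, no measured step covers this change; the one step known exchanges a thiophene for the pyrazole rather than shifting the attachment within the pyrazole, so it bears only indirectly, showing that the group at this position can move the number modestly. A step of similar or smaller size is therefore expected, direction uncertain but leaning toward a lower number because compound 1 gives 19 nM with a carbon-linked five-membered ring. Compound 3 is estimated at 40 nM, with a range from 15 nM to 120 nM. This corresponds to an expected step of a 1.8-fold lower number from compound 2 to compound 3 (0.24 log units; within the scatter).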

Compound 3, half-maximal inhibitory concentration: 270 nM
Estimate against measurement, compound 3: 6.8-fold (0.83 log units) below; measured number above the stated range.
By their numbers in this assay, from the lowest: compound 1; then compound 2; then compound 3.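

In this assay the same atoms joined differently give a 3.9-fold higher number from compound 2 to compound 3 (0.59 log units; beyond the scatter) and so the point of attachment within the pyrazole matters at this position. A carbon-linked five-membered ring does not by itself hold the number low: the exchange of thiophen-3-yl for 1H-pyrazol-4-yl, both joined through carbon, gives a 14-fold higher number from compound 1 to compound 3 (1.15 log units; beyond the scatter) and brings in 1 hydrogen-bond donor. Nothing at hand explains why either change raises the number.

As far as these compounds go, whether the hydrogen-bond donor of compound 3 is tied to its higher number stays open, and a 1-methyl-1H-pyrazol-4-yl group at the same place would bear on that question. From the compounds shown here alone, how a 1H-imidazol-1-yl group or a pyridin-3-yl ring would compare with these three compounds also remains open.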